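The Same Aryl Swap Tried on Two Related Cores

The compounds below may be only part of what the source reports. "The series", "measured", "known", "first", "only" and "open" are said of these compounds alone.

Four compounds built on one shared core are compared in a functional assay on HepG2 cells (Homo sapiens) for cytotoxicity, read by MTT assay, with a stated time of 72 h; a higher number here means a weaker inhibitor, a lower number a stronger inhibitor. Compound 1 `CNC(=O)c1cc(Oc2ccc(C3=NNC(c4ccc(C#N)cc4)C3)cc2)ccn1` gives 15000 nM. Compound 2 `CNC(=O)c1cc(Oc2ccc(C3=NNC(c4cccc(Cl)c4Cl)C3)cc2)ccn1` gives 4990 nM. Compound 3 `CNC(=O)c1cc(Oc2ccc(C3=NN(C(N)=S)C(c4cccc(Cl)c4Cl)C3)cc2)ccn1` gives 1890 nM, the lowest of the three numbers. Compound 4 `CNC(=O)c1cc(Oc2ccc(C3=NN(C(N)=S)C(c4ccc(C#N)cc4)C3)cc2)ccn1` has not yet been measured.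

Compound 2 and compound 1 differ in one place: 4-cyanophenyl in place of 2,3-dichlorophenyl on a saturated ring carbon. This change produced a 3.0-fold higher number from compound 2 to compound 1 (0.48 log units; beyond the scatter). Compound 3 differs from compound 2 in one place: a group of 3 heavy atoms (1 carbon, 1 nitrogen, 1 sulfur; no ring) in place of a hydrogen atom, on an amine nitrogen in a ring. This change produced a 2.6-fold lower number from compound 2 to compound 3 (0.42 log units; beyond the scatter), and it is also the whole difference between the core of compound 3 and compound 4 and the core of compound 1 and compound 2.

Compound 4 differs from compound 3 by 4-cyanophenyl in place of 2,3-dichlorophenyl on a saturated ring carbon. This is the same kind of change as from compound 2 to compound 1, but not the same: in compound 3 the saturated ring carbon is next to the ring atom that bears a group of 3 heavy atoms, whereas in compound 2 that ring nitrogen still carries its hydrogen. Among the measured compounds shown here, only this one earlier example of the swap exists, so the expectation rests on it alone. Compound 4 is expected to show a 3.0-fold higher number from compound 3 to compound 4 (0.48 log units; beyond the scatter), a weakening of about the same size, because a 3.0-fold higher number from compound 2 to compound 1 (0.48 log units; beyond the scatter) was observed when the identical swap was made. Compound 4 is therefore estimated at 5700 nM, most likely falling between 2500 nM and 13000 nM.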

Compound 4, half-maximal inhibitory concentration: > 50000 nM
Compound 4 was reported as a limit; the forecaster's own chance of this, stated with the estimate: 5%; middle value at least 8.7-fold (0.94 log units) from the limit.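

Replacing 2,3-dichlorophenyl with 4-cyanophenyl raises the number on both cores in this assay, so the direction carries over, but the size does not, with an at least 26-fold higher number from compound 3 to compound 4 (1.42 log units; beyond the scatter) on the core that carries the group of 3 heavy atoms: the same change on two cores in this assay, a 3.0-fold higher number (0.48 log units; beyond the scatter) from compound 2 to compound 1 and an at least 26-fold higher number (1.42 log units; beyond the scatter) from compound 3 to compound 4, at least 8.8-fold (0.94 log units) apart, beyond the scatter of two such steps

The group of 3 heavy atoms on the ring nitrogen does not carry over even in direction, giving a 2.6-fold lower number from compound 2 to compound 3 (0.42 log units; beyond the scatter) with 2,3-dichlorophenyl but an at least 3.3-fold higher number from compound 1 to compound 4 (0.52 log units; beyond the scatter) with 4-cyanophenyl: the same change on two cores in this assay, a 2.6-fold lower number (0.42 log units; beyond the scatter) from compound 2 to compound 3 and an at least 3.3-fold higher number (0.52 log units; beyond the scatter) from compound 1 to compound 4, at least 8.8-fold (0.94 log units) apart, beyond the scatter of two such steps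

On these data alone, compound 4 stands only as a limit of the assay (> 50000 nM), and the true size of both steps to it remains unknown. A single pair of cores cannot show how other aryl groups would behave.

As far as these compounds go, whether the larger step follows the loss of the two chlorines or the arrival of the nitrile stays open, and a phenyl ring with a single chlorine or an unsubstituted phenyl ring could help to separate the two. Also open, from the compounds shown here alone, is whether an acetyl group or a methyl group on that ring nitrogen would behave like the group of 3 heavy atoms.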